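Swapping a Ring Amine for Hydroxy on a Chalcone Arm

The compounds below may be only part of what the source reports. "The series", "measured", "known", "first", "only" and "open" are said of these compounds alone.

Of the compounds shown here, two sharing one core have been measured in a functional assay on SK-OV-3 cells (Homo sapiens) for antiproliferative activity, read by MTT assay, with a stated time of 24 h; on this read-out lower numbers stand for stronger inhibition and higher numbers for weaker inhibition. Compound 1 `COc1ccc(C(=O)/C=C/c2ccc3ccccc3c2)c2c1C=CC(C)(C)O2` carries a fused two-ring aromatic arm; in this assay compound 1 gives 7650 nM. Compound 2 `COc1ccc(C(=O)/C=C/c2ccc(N3CCCC3)cc2)c2c1C=CC(C)(C)O2` instead carries a single aromatic ring bearing pyrrolidin-1-yl; in this assay compound 2 gives 7370 nM. These two values sit within the usual scatter of each other, so neither compound can be called the more active of the pair on this evidence.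

Compound 3 `COc1ccc(C(=O)/C=C/c2ccc(O)cc2)c2c1C=CC(C)(C)O2` is the next variation. Relative to compound 2, it differs as follows: hydroxy in place of pyrrolidin-1-yl on an aromatic carbon. Among the measured compounds shown here, no measured pair illustrates a change of exactly this kind, so the expectation rests only on the two numbers above, which both sit at a similar, modest level. The step from compound 2 to compound 3 is expected to be small, a 1.3-fold higher number from compound 2 to compound 3 (0.11 log units; within the scatter), leaning toward a slightly higher number. Compound 3 is therefore estimated at 9500 nM, with a plausible range from 3500 nM to 26000 nM.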

Compound 3, half-maximal inhibitory concentration: > 10000 nM
Compound 3: only a limit was reported; the forecaster's own chance of this, stated with the estimate: 15%; at least 1.0-fold (0.02 log units) between middle value and limit.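

In this assay compound 3 gives > 10000 nM, which is a limit of the assay and not a number. Placing hydroxy where pyrrolidin-1-yl stood, on an aromatic carbon para to a large group, gives an at least 1.3-fold higher number from compound 2 to compound 3 (0.13 log units; that floor lies within the scatter). This is the first single-place change in the series, and it shows that this small group brings no gain in inhibition over the ring amine, although the true size of the step remains unknown, and the only reading of this kind is: the limit of > 10000 nM in this assay, at which 1 of the 3 values shown sits.

The compounds shown leave open how an open-chain amine such as dimethylamino, or a carboxylic acid, would read at this same place. They also cannot separate the effect of losing the pyrrolidin-1-yl ring from the effect of adding hydroxy, since a single swap changes both at once.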